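Difluorophenyl Amide Compared With Its Unsubstituted Parent

The compounds below may be only part of what the source reports. "The series", "measured", "known", "first", "only" and "open" are said of these compounds alone.

Compound 1 `CC(C)c1cccc(C(C)C)c1OC(=O)CC(=O)Nc1ccccc1` was examined in an assay on microsomes from intestine for inhibition of acyl-CoA:cholesterol acyltransferase (Oryctolagus cuniculus); a higher number here means a weaker inhibitor, a lower number a stronger inhibitor. In this assay compound 1 gives only > 5000 nM, which is a limit of the assay and not a number. The reversed ester-amide compound 2 `CC(C)c1cccc(C(C)C)c1NC(=O)CC(=O)Oc1c(C(C)C)cccc1C(C)C` gives 42 nM in this assay. Compound 3 `CC(C)c1cccc(C(C)C)c1OC(=O)CC(=O)Nc1c(F)cccc1F` differs from compound 1 by 2,6-difluorophenyl in place of phenyl on an amide-type nitrogen. Among the compounds with values here, no measured pair spans this change, so the step that the limit leaves unreadable from compound 1 to compound 3 is expected to be small, if any beyond the scatter. Compound 3 is therefore estimated at 6000 nM, within 1500 nM to 30000 nM, and most likely is again reported only as a limit.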

Compound 3, half-maximal inhibitory concentration: 6200 nM
Compound 3: middle estimate off by 1.0-fold (0.01 log units), on the low side, within the range that was stated.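

No step from compound 1 to compound 3 can be read, because compound 1 stands only at a limit of the assay: the limit of > 5000 nM in this assay, at which 1 of the 3 values shown sits.

Going by these compounds, whether 2,6-difluorophenyl in place of phenyl on an amide-type nitrogen changes the inhibition at all remains open.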